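Propoxycarbonyl to benzyloxycarbonyl in a growth assay

The source may hold more compounds than are shown below. What is called first, only, known or untested is meant among the compounds shown, and "the series" means these compounds.

Measured in a functional assay on HT-29 cells (Homo sapiens) for antiproliferative activity, read by MTT assay, with a stated time of 48 h; a lower number here means a stronger inhibitor of growth, a higher number a weaker inhibitor of growth:
Compound 1 `COc1cc(C2CC(c3ccccc3)=NN2C(=O)OCc2ccccc2)cc(OC)c1OC`: > 10000 nM
Compound 2 `CCCOC(=O)N1N=C(c2cccc(OC)c2)CC1c1cc(OC)c(OC)c(OC)c1`: > 10000 nM

Compound 2 stands at the limit of > 10000 nM in this assay, at which 2 of the 2 values shown sit. This is a limit and not a number, so it gives no exact starting point for comparison.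

Compound 3 `COc1cccc(C2=NN(C(=O)OCc3ccccc3)C(c3cc(OC)c(OC)c(OC)c3)C2)c1` has not yet been measured. It differs from compound 2 in one place: phenyl in place of ethyl on a saturated chain carbon bound to an oxygen next to a carbonyl group. Phenyl takes the place of ethyl on a saturated chain carbon bound to an oxygen next to a carbonyl group, so propoxycarbonyl becomes benzyloxycarbonyl.

For the measured compounds named here, no measured pair shows what this change does, and neither measured compound has an exact value. In this assay, the expected step that the limit leaves unreadable from compound 2 to compound 3 is small and has no clear direction. A further result reported only as a limit is the most likely outcome. Compound 3 is estimated at 12000 nM, with an expected range of 3000 nM to 40000 nM.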

Compound 3, concentration for 50% growth inhibition: > 10000 nM
Compound 3: no number, only a limit; the forecaster's own chance of this, stated with the estimate: 70%; the middle value does not contradict the limit.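

In this assay, compound 1, compound 2 and compound 3 are all reported only as limits and not as numbers, so the steps from compound 2 and from compound 1 to compound 3 cannot be read. Going by these compounds, whether benzyloxycarbonyl in place of propoxycarbonyl, or methoxy in place of hydrogen, changes growth inhibition at all remains open.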